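The compounds below may be only part of what the source reports. "The series", "measured", "known", "first", "only" and "open" are said of these compounds alone.

In a functional assay on MDA-MB-231 cells (Homo sapiens) for antiproliferative activity, read by MTT assay, with a stated time of 72 h (on this read-out higher numbers stand for weaker inhibition and lower numbers for stronger inhibition), the measured compounds read as follows:

- Compound 1 `CC1=CCC2C(CC[C@@]2(C)O)C(C)(C)C1CC[C@@H]1[C@@]2(C)CC[C@@H](O)C(C)(C)O[C@@H]2CC[C@]1(C)O` gives > 50000 nM as a limit
- Compound 2 `CC1=CC[C@H]2[C@@H]1CC=C(C)[C@@H](CC[C@H]1[C@]3(C)CC[C@H](O)C(C)(C)O[C@H]3CC[C@@]1(C)O)C2(C)C` gives > 50000 nM as a limit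
- Compound 3 `CC1=CC[C@H]2[C@H](CC[C@]2(C)O)C(C)(C)[C@@H]1CC[C@H]1[C@]2(C)CC[C@H](OC(=O)c3ccccc3)C(C)(C)O[C@H]2CC[C@@]1(C)O` gives 16100 nM as a number

Compound 3 alone has a real number, while the other two values are limits (the limit of > 50000 nM in this assay, at which 2 of the 3 values shown sit). Compound 4 `CC1=CC[C@H]2[C@H](CC[C@]2(C)O)C(C)(C)[C@@H]1CC[C@H]1[C@]2(C)CC[C@H](OC(=O)c3ccc(Cl)cc3)C(C)(C)O[C@H]2CC[C@@]1(C)O` matches compound 3 except for chloro in place of hydrogen on an aromatic carbon, para to a large group (chloro in place of hydrogen on an aromatic carbon), turning phenyl into 4-chlorophenyl. Among the compounds with values here, no measured pair shows what this change does in this assay so only a small shift toward stronger inhibition is expected. The expected step of a 1.3-fold lower number from compound 3 to compound 4 (0.13 log units; within the scatter) stays close to the usual scatter. Compound 4 is estimated at 12000 nM with an expected range from 5000 nM to 30000 nM once measured.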

Compound 4, half-maximal inhibitory concentration: 10300 nM
Beside the measured number, compound 4's estimate is 1.2-fold (0.07 log units) above it; measured number inside the range.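

In this assay, within the data shown here, the change from phenyl to 4-chlorophenyl gives the first direct reading of this position, with a 1.6-fold lower number from compound 3 to compound 4 (0.19 log units; within the scatter) as its step. Chloro in place of hydrogen here, para to a large group, therefore moves the number no further than repeated measurements of one compound could. Nothing shown gives a reason for this result.

Going by these compounds, whether an amine or a carboxylic acid at this same place would shift the number beyond the scatter stays open. So does the effect of chloro elsewhere on this aromatic ring.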